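Methyl for methoxy at the assay limit

This account rests on a few compounds, and the source may have more. Where it says the series, first, only, none or still open, it means among the compounds named here.

In a functional assay on SK-OV-3 cells (Homo sapiens) for cytotoxicity, read by MTT assay, with a stated time of 24 h (on this read-out higher numbers stand for weaker inhibition and lower numbers for stronger inhibition), compound 1 (`C#CCn1c(=O)c(C=O)cc2ccccc21`) gives > 100000 nM as a limit. Compound 2 (`C#CCn1c(=O)c(C=O)cc2cc(Cl)ccc21`) gives > 100000 nM as a limit too. Compound 3 (`C#CCn1c(=O)c(C=O)cc2cc(OC)ccc21`) gives > 100000 nM as a limit as well, so it offers no number to start from. Compound 4 (`C#CCn1c(=O)c(C=O)cc2cc(C)ccc21`) differs from compound 3 by methyl in place of methoxy on an aromatic carbon. Going by the values given here, the steps that bear on this are a step that the two limits leave unreadable from compound 1 to compound 3 and a step that the two limits leave unreadable from compound 2 to compound 3 and a step that the two limits leave unreadable from compound 1 to compound 2 and none of them has a readable size. No step beyond the scatter and no direction is expected in this assay and the estimated step is a number no higher from compound 3 to compound 4 (the limit leaves the size open) for now. Compound 4 is estimated at 100000 nM with an expected range of 50000 nM to 200000 nM and will most likely be reported only as a limit.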

Compound 4, half-maximal inhibitory concentration: > 100000 nM
Compound 4: a limit, no number; the forecaster's own chance of this, stated with the estimate: 85%; the middle value sits exactly at the limit.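

The steps from compound 1, compound 2 and compound 3 to compound 4 cannot be read, as all four stand at one limit: the limit of > 100000 nM in this assay, at which 4 of the 4 values shown sit.

The compounds shown leave open whether any group at this place on the shared core gives a readable value in this assay.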